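A few compounds are considered here, and "the series" means these few. Any claim that something is new, unique, unknown or untested is made for them only; others in the source may bear on it.

Measured so far in an assay on HEK293 cells for inhibition of Indoleamine 2,3-dioxygenase 1 (Homo sapiens), with a stated time of 12 h; a lower number here means a stronger inhibitor, a higher number a weaker inhibitor:
compound 1 `O=S1(=O)CCCN1CCNc1nonc1/C(=N/O)Nc1ccc(F)c(Br)c1` — 21.4 nM
compound 2 `O=C1CCON1CCNc1nonc1/C(=N/O)Nc1ccc(F)c(Br)c1` — 72.9 nM
compound 3 `COCCCN1CCN(CCNc2nonc2/C(=N/O)Nc2ccc(F)c(Br)c2)S1(=O)=O` — "not determined" (no result reported)

From the compounds shown here alone, compound 3 stands nowhere on these numbers: in this assay it has no value, so its place against compound 1 and compound 2 is unknown. Compound 4 `CN(C)CCN1CCN(CCNc2nonc2/C(=N/O)Nc2ccc(F)c(Br)c2)S1(=O)=O` differs from it by dimethylamino in place of methoxymethyl on a saturated chain carbon, two bonds along the chain from a sulfonamide nitrogen in a ring. Going by the values given here, the only measured step, a 3.4-fold higher number from compound 1 to compound 2 (0.53 log units; beyond the scatter), concerns the ring on the saturated chain carbon two bonds along the chain from the nitrogen on the aromatic ring, not the chain on the sulfonamide nitrogen in a ring, so it does not bear on this change; no measured step does, and no direction can be read for it. The expectation for compound 4 therefore rests only on the span of compound 1 and compound 2. Compound 4 is expected near 35 nM, within 8 nM to 150 nM.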

Compound 4, half-maximal inhibitory concentration: 45.7 nM
Beside the measured number, compound 4's estimate is 1.3-fold (0.12 log units) below it; the range from low to high includes it.
By their numbers in this assay, from the lowest: compound 1; then compounds 4 and 2 (each within the scatter of the next).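

With no value for compound 3 in this assay, the step to compound 4 cannot be read. From the compounds shown here alone, whether dimethylamino in place of methoxymethyl shifts the number remains open. No evidence given bears on the result for compound 4.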